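The source may hold more compounds than are shown below. What is called first, only, known or untested is meant among the compounds shown, and "the series" means these compounds.

Compound 1 `O=C(C1=C(O)C(=O)N(CCCn2ccnc2)C1c1ccc(Br)cc1)c1ccccc1`: 20000 nM in a functional assay on NCI-H1299 cells (Homo sapiens) for antiproliferative activity, read by MTT assay, with a stated time of 72 h; on this read-out lower numbers stand for stronger inhibition and higher numbers for weaker inhibition
Compound 2 `CCOC1=C(C(=O)c2ccccc2)C(c2ccc(Br)cc2)N(CCCn2ccnc2)C1=O`: 28900 nM in this assay
Compound 3 `NC1=C(C(=O)c2ccccc2)C(c2ccc(Br)cc2)N(CCCn2ccnc2)C1=O`: 169000 nM in this assay

Among these three numbers compound 1 stands lowest. Its nearest neighbour is compound 2, with a 1.4-fold higher number from compound 1 to compound 2 (0.16 log units; within the scatter), a change that lies within the scatter; its furthest is compound 3, with an 8.5-fold higher number from compound 1 to compound 3 (0.93 log units; beyond the scatter), a modest loss that lies beyond the scatter.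

Compound 4 `Cc1ccc(NC2=C(C(=O)c3ccccc3)C(c3ccc(Br)cc3)N(CCCn3ccnc3)C2=O)cc1` differs from compound 1 in one place: (4-methylphenyl)amino in place of hydroxy on a double-bonded ring carbon.

For the measured compounds named here, two measured steps bear on this change, since both put a nitrogen where the oxygen of compound 1 sits. From the hydroxy of compound 1 to the amino of compound 3 the number rose by an 8.5-fold higher number from compound 1 to compound 3 (0.93 log units; beyond the scatter), and from the ethoxy of compound 2 to the same amino by a 5.8-fold higher number from compound 2 to compound 3 (0.77 log units; beyond the scatter). Going by the values given here, no measured compound carries a (4-methylphenyl)amino at this carbon, so the weight of that group is untested here. On the evidence of compound 3, a step toward a higher number, that is weaker inhibition, is expected, of about a 2.3-fold higher number from compound 1 to compound 4 (0.35 log units; beyond the scatter). Compound 4 is therefore estimated at 45000 nM, within a range from 10000 nM to 200000 nM.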

Compound 4, half-maximal inhibitory concentration: 25800 nM
The estimate for compound 4 lay 1.7-fold (0.24 log units) above the measured number; low and high end bracket the measured number.
By their numbers in this assay, from the lowest: compounds 1, 4 and 2 (each within the scatter of the next); then compound 3.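

At this double-bonded ring carbon, the plain amino of compound 3 does not settle what a nitrogen does here: 4-methylphenyl on that amine nitrogen gives a 6.6-fold lower number from compound 3 to compound 4 (0.82 log units; beyond the scatter) in this assay and so removes the loss that compound 3 had shown. Set against the oxygen groups, the (4-methylphenyl)amino cannot be told apart from them, with a 1.3-fold higher number from compound 1 to compound 4 (0.11 log units; within the scatter) for the swap from hydroxy and a 1.1-fold lower number from compound 2 to compound 4 (0.05 log units; within the scatter) for the swap from ethoxy. Among these compounds, then, a nitrogen at this carbon does not by itself bring a loss, and a group carrying a six-membered aromatic ring of carbon only is accepted here, with compound 3 alone standing apart from the other three.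

Going by these compounds, it remains open whether the recovery comes from the aromatic ring itself or from the methyl on it, and what a plain phenylamino, a 4-chlorophenylamino or a benzylamino at this carbon would give. Nothing measured on these compounds explains the steps seen here.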